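This account rests on a few compounds, and the source may have more. Where it says the series, first, only, none or still open, it means among the compounds named here.

Compound 1 `Cc1cccc(Cn2cc(COc3ccc4c(=O)ccoc4c3)nn2)c1` gives 20300 nM in a functional assay on A549 cells (Homo sapiens) for cytotoxicity, read by MTT assay, with a stated time of 48 h; a lower number here means a stronger inhibitor, a higher number a weaker inhibitor.
Compound 2 `O=c1ccoc2cc(OCc3cn(Cc4cccc(Br)c4)nn3)ccc12` reaches only the assay limit, > 100000 nM, in this assay.
Compound 3 `O=c1ccoc2cc(OCc3cn(Cc4ccc(Cl)cc4Cl)nn3)ccc12` gives 5260 nM in this assay.

Among these three, compound 3 stands lowest, with the nearest number belonging to compound 1, a step of a 3.9-fold lower number from compound 1 to compound 3 (0.59 log units; beyond the scatter). Compound 2 sits at a limit, as the limit of > 100000 nM in this assay, at which 1 of the 3 values shown sits, records, so its distance from compound 3 is known only as an at least 19-fold lower number from compound 2 to compound 3 (1.27 log units; beyond the scatter).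

Compound 4 `O=c1ccoc2cc(OCc3cn(Cc4ccc(Br)cc4)nn3)ccc12` is not yet measured. It differs from compound 3 in one place: 4-bromophenyl in place of 2,4-dichlorophenyl on a saturated chain carbon bound to an aromatic nitrogen. The measured steps that bear on this are those in which the group on the same saturated chain carbon changes: the step of a 3.9-fold lower number from compound 1 to compound 3 (0.59 log units; beyond the scatter) and the step of an at least 19-fold lower number from compound 2 to compound 3 (1.27 log units; beyond the scatter). Both show that moving away from the 2,4-dichlorophenyl group toward a singly substituted phenyl group gave a higher number, modestly in one case and at least largely in the other. A higher number in this assay is therefore expected for compound 4, by a step of about a 4.8-fold higher number from compound 3 to compound 4 (0.68 log units; beyond the scatter). The estimate for compound 4 is 25000 nM, within a range from 8000 nM to 100000 nM.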

Compound 4, half-maximal inhibitory concentration: > 100000 nM
Compound 4: only a limit was reported (the forecaster's own chance of this, stated with the estimate: 25%); at least 4.0-fold (0.60 log units) between middle value and limit.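

In this assay, replacing 2,4-dichlorophenyl with 4-bromophenyl on the saturated chain carbon bound to an aromatic nitrogen gives an at least 19-fold higher number from compound 3 to compound 4 (1.27 log units; beyond the scatter), while replacing 3-methylphenyl with it gives an at least 4.9-fold higher number from compound 1 to compound 4 (0.69 log units; beyond the scatter). These steps show that the poor result is not confined to 3-bromophenyl, since a second bromophenyl group also falls well behind the 2,4-dichlorophenyl group of compound 3. Compound 2 and compound 4 both stop at a limit of the assay, so the step between them cannot be read: the limit of > 100000 nM in this assay, at which 2 of the 4 values shown sit.

As far as these compounds go, whether the bromine itself matters, or only the pattern of substitution on the ring, remains open, and a 4-chlorophenyl or 2,4-dibromophenyl group could separate the two. From the compounds shown here alone, how an amine or a carboxylic acid on this ring would read also remains open.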